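The compounds below may be only part of what the source reports. "The series", "measured", "known", "first", "only" and "open" are said of these compounds alone.

Going by the values given here, compound 2 `CC(C)(C)c1ccc(C(=O)N2CCC3(CC2)C(=O)N(CC(=O)N2CCCCC2CO)CN3c2ccccc2)cc1` gives 11800 nM in an assay on HEK293 cells for displacement of a labelled ligand from NPC1-like intracellular cholesterol transporter 1 (Homo sapiens) (on this read-out higher numbers stand for weaker inhibition and lower numbers for stronger inhibition), the highest of the two numbers measured so far, while compound 1 `CC(C)(C)c1ccc(C(=O)N2CCC3(CC2)C(=O)N(CC(=O)N2CCC(O)CC2)CN3c2ccccc2)cc1` gives 4700 nM. Compound 3 `CC(C)(C)c1ccc(C(=O)N2CCC3(CC2)C(=O)N(CC(=O)N2CCCC(CO)C2)CN3c2ccccc2)cc1` differs from compound 2 by 3-(hydroxymethyl)piperidin-1-yl in place of 2-(hydroxymethyl)piperidin-1-yl on a carbonyl carbon. Among the compounds with values here, the one measured step on the same carbonyl carbon, a 2.5-fold higher number from compound 1 to compound 2 (0.40 log units; beyond the scatter), exchanged one hydroxyl-bearing ring for another and was modest; it does not involve the 3-(hydroxymethyl)piperidin-1-yl group, so it bears only loosely here. A small move back downward is therefore expected, a 1.5-fold lower number from compound 2 to compound 3 (0.17 log units; within the scatter), with the direction uncertain. Compound 3 is estimated at 8000 nM, within 3000 nM to 20000 nM.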

Compound 3, half-maximal inhibitory concentration: 8200 nM
For compound 3 the middle estimate is 1.0-fold (0.01 log units) below the measured one; the measured number falls inside the stated range.
By their numbers in this assay, from the lowest: compounds 1, 3 and 2 (each within the scatter of the next, the first and the last beyond it).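

In this assay, the shift to 3-(hydroxymethyl)piperidin-1-yl on this carbonyl carbon gives a 1.4-fold lower number from compound 2 to compound 3 (0.16 log units; within the scatter), and the exchange of 4-hydroxypiperidin-1-yl for the same group gives a 1.7-fold higher number from compound 1 to compound 3 (0.24 log units; within the scatter). Going by these compounds alone, compound 3 is thus separated from neither of the other two, and only the step between compound 1 and compound 2 remains beyond the scatter. Going by these compounds, whether plain piperidin-1-yl, without a hydroxyl, or a ring carrying an amine or a carboxylic acid would read differently at this position stays open. Nothing available explains these readings.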